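Methyl in Place of Methoxy on the Terminal Aryl Ring

The source may hold more compounds than are shown below. What is called first, only, known or untested is meant among the compounds shown, and "the series" means these compounds.

Compound 1: `COc1ccc(-c2ccnc(C(=O)Nc3ccc(Oc4ccnc5[nH]ccc45)cc3)n2)cc1`; in a functional assay on MCF7 cells (Homo sapiens) for cytotoxicity, read by MTT assay, with a stated time of 72 h (a higher number here means a weaker inhibitor, a lower number a stronger inhibitor), compound 1 gives 12400 nM.
Compound 2: `COc1ccc(-c2cc(C(=O)Nc3ccc(Oc4ccnc5[nH]ccc45)cc3)ncn2)cc1`; in this assay compound 2 gives 4450 nM.

Among the measured compounds shown here, of the two numbers measured so far, compound 2 stands lowest; compound 1 gives a higher number, and that gap lies beyond the usual scatter. The two compounds differ in more than one place, so their values are only compared, not read as a single step.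

Compound 3, `Cc1ccc(-c2cc(C(=O)Nc3ccc(Oc4ccnc5[nH]ccc45)cc3)ncn2)cc1`, is the unmeasured one. It differs from compound 2 by methyl in place of methoxy on an aromatic carbon. For the measured compounds named here, no pair of measured compounds shows this change, so nothing here gauges its size. The expectation for the step from compound 2 to compound 3 is a 1.1-fold higher number from compound 2 to compound 3 (0.05 log units; within the scatter), a move not beyond the scatter in either direction. Compound 3 is therefore estimated at 5000 nM in this assay, within a range from 1500 nM to 16000 nM.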

Compound 3, half-maximal inhibitory concentration: 1620 nM
For compound 3 the middle estimate is 3.1-fold (0.49 log units) above the measured one; measured number inside the range.
By their numbers in this assay, from the lowest: compound 3; then compound 2; then compound 1.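

Changing 4-methoxyphenyl to 4-methylphenyl gives, in this assay, a 2.7-fold lower number from compound 2 to compound 3 (0.44 log units; beyond the scatter) and so shows that the group on this aromatic carbon, para to a large group, affects the number. Among the compounds shown here, this is the first single-change reading at this position, as compound 1 and compound 2 differ in more than one place, and it shows that methoxy is not required here for cytotoxicity in these cells. Nothing measured here accounts for the size or direction of this step.

As far as these compounds go, whether an ethyl group, a chlorine, an amine or a bare hydrogen at the same position would lower the number further or raise it remains open. So does whether methyl in place of methoxy has a similar effect on the core of compound 1.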